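Swapping Phenyl for Furan-2-yl on a Cytotoxic Nucleoside

This account rests on a few compounds, and the source may have more. Where it says the series, first, only, none or still open, it means among the compounds named here.

Two related compounds have been tested so far for how strongly they harm cultured cells. In a functional assay on HeLa S3 cells (Homo sapiens) for cytotoxicity, read by XTT assay, with a stated time of 3 days (on this read-out higher numbers stand for weaker inhibition and lower numbers for stronger inhibition), compound 2 (`OC[C@H]1O[C@@H](n2cc(Cl)c3c(-c4ccccc4)ncnc32)[C@H](O)[C@@H]1O`) gives 420 nM, the lower of the two numbers, so less of it is needed for the same effect. Compound 1 (`OC[C@H]1O[C@@H](n2cc(F)c3c(-c4ccco4)ncnc32)[C@H](O)[C@@H]1O`) gives 8000 nM, and that gap lies well beyond the scatter of repeat measurements.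

The next compound to test is compound 3 (`OC[C@H]1O[C@@H](n2cc(Cl)c3c(-c4ccco4)ncnc32)[C@H](O)[C@@H]1O`). It has furan-2-yl in place of phenyl on an aromatic carbon of the shared core: furan-2-yl in place of phenyl on an aromatic carbon. Everything else in compound 2 stays the same, so any shift in this assay can be traced to this one swap.

Going by the values given here, no two measured compounds differ in only one place, so the data offer no direct guide to the size of this step. The cautious expectation is therefore no change beyond the scatter, with real room in either direction. The estimated change is a 1.2-fold lower number from compound 2 to compound 3 (0.08 log units; within the scatter). Compound 3 is expected to give about 350 nM, with an estimated range of 50 nM to 2500 nM.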

Compound 3, half-maximal inhibitory concentration: > 40000 nM
Compound 3: only a limit was reported (the forecaster's own chance of this, stated with the estimate: 5%); middle value at least 110-fold (2.05 log units) from the limit.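

In this assay compound 3 gives > 40000 nM, which is a limit of the assay and not a number: the limit of > 40000 nM in this assay, at which 1 of the 3 values shown sits. With chloro kept in place, furan-2-yl in place of phenyl gives an at least 95-fold higher number from compound 2 to compound 3 (1.97 log units; beyond the scatter), so the group on this aromatic carbon of the shared core strongly shapes the result, and these two aromatic rings are far from interchangeable here. With furan-2-yl kept in place, chloro in place of fluoro gives an at least 5.0-fold higher number from compound 1 to compound 3 (0.69 log units; beyond the scatter), which shows that the halogen also matters, something the first two compounds could not show, as they differ in both places at once.

As far as these compounds go, it remains open whether phenyl is the key to the lower number in compound 2 or whether other groups on this carbon, such as thiophen-2-yl, a methyl group or an amine, could serve as well. From the compounds shown here alone, it also remains open whether phenyl would keep its advantage over furan-2-yl with fluoro in place of chloro, since the size of one swap may depend on the other.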